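A second chloro on the benzylidene arm of compound 2

A few compounds are considered here, and "the series" means these few. Any claim that something is new, unique, unknown or untested is made for them only; others in the source may bear on it.

Measured so far:
compound 1, `COc1ccc(C2C(C#N)=C(/N=C/c3ccccc3)Oc3nc(Nc4ccc(S(N)(=O)=O)cc4)sc32)cc1`, 33600 nM
compound 2, `COc1ccc(C2C(C#N)=C(/N=C/c3ccc(Cl)cc3)Oc3nc(Nc4ccc(S(N)(=O)=O)cc4)sc32)cc1`, 9550 nM
compound 3, `COc1ccc(C2C(C#N)=C(/N=C/c3cccc(Br)c3)Oc3nc(Nc4ccc(S(N)(=O)=O)cc4)sc32)cc1`, 9390 nM

In a functional assay on MCF7 cells (Homo sapiens) for cytotoxicity, read by sulforhodamine B assay, with a stated time of 48 h (on this read-out higher numbers stand for weaker inhibition and lower numbers for stronger inhibition), compound 2 gives 9550 nM, the second highest of the three numbers; compound 3 stands close to it, since a 1.0-fold lower number from compound 2 to compound 3 (0.01 log units; within the scatter), while compound 1 stands furthest away, with a 3.5-fold lower number from compound 1 to compound 2 (0.55 log units; beyond the scatter). Compound 4, `COc1ccc(C2C(C#N)=C(/N=C/c3ccc(Cl)cc3Cl)Oc3nc(Nc4ccc(S(N)(=O)=O)cc4)sc32)cc1`, is not yet measured. It differs from compound 2 by chloro in place of hydrogen on an aromatic carbon, so that the 4-chlorophenyl of compound 2 becomes a 2,4-dichlorophenyl.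

The measured steps that bear on this change are the two halogen additions to the unsubstituted ring: a 3.5-fold lower number from compound 1 to compound 2 (0.55 log units; beyond the scatter) and a 3.6-fold lower number from compound 1 to compound 3 (0.55 log units; beyond the scatter). Both lowered the number by a modest amount beyond the scatter. Whether a second halogen on the same ring repeats that gain is not shown by the measured compounds, so a smaller step is expected than the first. Compound 4 is therefore expected to give 6000 nM in this assay, with a range from 2500 nM to 15000 nM, which corresponds to an expected step of a 1.6-fold lower number from compound 2 to compound 4 (0.20 log units; within the scatter).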

Compound 4, half-maximal inhibitory concentration: 23500 nM
Compound 4: middle estimate off by 3.9-fold (0.59 log units), on the low side, and the stated range ends below it.
By their numbers in this assay, from the lowest: compounds 3 and 2 (each within the scatter of the next); then compounds 4 and 1 (each within the scatter of the next).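

In this assay, the second chloro, placed ortho to a large group and meta to a chloro group, does not add to the gain from the first halogen: the change gives a 2.5-fold higher number from compound 2 to compound 4 (0.39 log units; beyond the scatter). The 2,4-dichlorophenyl also compares poorly with the 3-bromophenyl, with a 2.5-fold higher number from compound 3 to compound 4 (0.40 log units; beyond the scatter), while a 1.4-fold lower number from compound 1 to compound 4 (0.16 log units; within the scatter) places it within the scatter of the plain phenyl, so the gain seen with a single halogen on this ring is lost with this second chloro. Nothing shown here gives a reason for this loss.

The compounds shown leave open whether the loss follows from this ring place alone or from the pairing of the two chloro groups. They also leave open how a fluoro, methoxy or amino group on that same carbon would read, with or without the 4-chloro.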